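A Trifluoromethyl Added to the Benzyl Group

A few compounds are considered here, and "the series" means these few. Any claim that something is new, unique, unknown or untested is made for them only; others in the source may bear on it.

Of the compounds shown here, three sharing one core have been tested in a functional assay on MGC-803 cells (Homo sapiens) for inhibition, read by MTT assay, with a stated time of 72 h; a lower number here means a stronger inhibitor, a higher number a weaker inhibitor. Compound 1 `CC(C)n1ncc2c(C(=O)NCc3cn(-c4cccc(F)c4)nn3)cccc21` carries a 3-fluorophenyl on an aromatic nitrogen, and in this assay compound 1 reaches only the limit > 40000 nM, not a number. Compound 2 `COc1ccc(-n2cc(CNC(=O)c3cccc4c3cnn4C(C)C)nn2)cc1` carries a 4-methoxyphenyl in that position, and compound 2 likewise reaches only the limit > 40000 nM. For the measured compounds named here, compound 3 `CC(C)n1ncc2c(C(=O)NCc3cn(Cc4ccccc4)nn3)cccc21` carries a benzyl group there, and in this assay compound 3 gives 14300 nM, the only measured number among the three, so that the steps of an at least 2.7-fold lower number from compound 1 to compound 3 (0.44 log units; beyond the scatter) and an at least 2.7-fold lower number from compound 2 to compound 3 (0.44 log units; beyond the scatter) both run toward the benzyl compound. Compound 4 `CC(C)n1ncc2c(C(=O)NCc3cn(Cc4ccc(C(F)(F)F)cc4)nn3)cccc21` differs from compound 3 by trifluoromethyl in place of hydrogen on an aromatic carbon. Going by the values given here, none of the measured steps touches this kind of change, since each of them swaps the whole group on the nitrogen rather than adding a substituent to the benzyl ring. The expectation therefore rests on compound 3 alone, and the step of a 1.2-fold lower number from compound 3 to compound 4 (0.08 log units; within the scatter) is expected to stay within the scatter. Compound 4 is estimated at 12000 nM, with a range from 5000 nM to 30000 nM.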

Compound 4, half-maximal inhibitory concentration: > 40000 nM
Compound 4: a limit, no number; the forecaster's own chance of this, stated with the estimate: 20%; middle value at least 3.3-fold (0.52 log units) away from the limit.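

Placing trifluoromethyl on the benzyl ring of compound 3, on an aromatic carbon para to a large group, moves the result in this assay toward a weaker inhibitor: the change is an at least 2.7-fold higher number from compound 3 to compound 4 (0.44 log units; beyond the scatter). For the compounds shown here, the earlier steps swapped the whole group on the nitrogen, whereas this one keeps the benzyl group and shows that a single added substituent on its ring is enough to lose the one measured number. Compound 4 gives > 40000 nM, a limit and not a number, so the full size of the step stays unknown, and compound 4 now sits with compound 1 and compound 2: the limit of > 40000 nM in this assay, at which 3 of the 4 values shown sit.

On these data alone, whether this loss belongs to trifluoromethyl alone or to any substituent at this place remains open. A fluorine, a methoxy or an amine on the same ring carbon would help to separate the two.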